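Swapping methoxy for bromo in a small series

The compounds below may be only part of what the source reports. "The series", "measured", "known", "first", "only" and "open" are said of these compounds alone.

compound 1 (`CC(=O)NNC(=O)c1csc2ncc(-c3ccc(C)cc3)n12`): 92700 nM
compound 2 (`COc1ccc(-c2cnc3scc(C(=O)NNC(C)=O)n23)cc1`): 28300 nM

In a functional assay on PC-3 cells (Homo sapiens) for antiproliferative activity, read by MTT assay, with a stated time of 72 h (a lower number here means a stronger inhibitor, a higher number a weaker inhibitor), compound 2 has the lower of the two numbers, at 28300 nM and so is the stronger inhibitor of this pair. Compound 3 (`CC(=O)NNC(=O)c1csc2ncc(-c3ccc(Br)cc3)n12`) has not yet been measured. It carries bromo in place of methoxy on an aromatic carbon, para to a large group (bromo in place of methoxy on an aromatic carbon).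

For the measured compounds named here, no compound with bromo has been measured, so only one step bears on this change, and only indirectly. That step is a 3.3-fold lower number from compound 1 to compound 2 (0.52 log units; beyond the scatter) with methoxy in place of methyl on an aromatic carbon. It shows that a single swap of this kind moved the number modestly, and that methoxy gave the lower number. Compound 3 gives up that methoxy. The expected step, estimated as a 2.1-fold higher number from compound 2 to compound 3 (0.33 log units; beyond the scatter) and so modest, points to a weaker inhibitor. In this assay the estimated value for compound 3 is 60000 nM (expected range 22000 nM to 140000 nM).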

Compound 3, half-maximal inhibitory concentration: 12700 nM
Estimate against measurement, compound 3: 4.7-fold (0.67 log units) above; measured number below the stated range.
By their numbers in this assay, from the lowest: compound 3; then compound 2; then compound 1.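

In this assay, giving up the methoxy did not cost activity at this position, as shown by a 2.2-fold lower number from compound 2 to compound 3 (0.35 log units; beyond the scatter), so methoxy's advantage over methyl did not make it the best of the three groups. Bromo gives the strongest inhibitor of the three, with a 7.3-fold lower number from compound 1 to compound 3 (0.86 log units; beyond the scatter) as well, and since it counts no hydrogen-bond acceptor, an acceptor on this aromatic carbon is not needed for the number to fall. Nothing in the data explains why the order of the three groups runs this way.

What the compounds shown leave open is whether another halogen, such as chloro or fluoro, would match bromo on this carbon. They also do not tell how an amine or a carboxylic acid would behave in the same place.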